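A few compounds are considered here, and "the series" means these few. Any claim that something is new, unique, unknown or untested is made for them only; others in the source may bear on it.

Compound 1 `CCn1c(C(=O)N[C@@H](CC(=O)OC)C(=O)OC)ccc1C(CC)(CC)c1ccc(OCS(=O)(=O)c2ccccc2)c(C)c1`: > 50000 nM
Compound 2 `CCn1c(C(=O)N[C@@H](CO)C(C)C)ccc1C(CC)(CC)c1ccc(OCS(=O)(=O)c2ccccc2)c(C)c1`: 13200 nM

In a functional assay on BXPC-3 cells (Homo sapiens) for antiproliferative activity, read by MTT assay, with a stated time of 24 h (on this read-out higher numbers stand for weaker inhibition and lower numbers for stronger inhibition), compound 1 gives > 50000 nM, which is a limit of the assay rather than a number. Compound 1 therefore stands at the limit of > 50000 nM in this assay, at which 1 of the 2 values shown sits. In this assay compound 2 gives 13200 nM. Within the data shown here, the one measured step that connects them is an at least 3.7-fold lower number from compound 1 to compound 2 (0.57 log units; beyond the scatter), so compound 1 sits at the weak end of the two values shown.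

Compound 3 `CCn1c(C(=O)N[C@@H](CO)CCO)ccc1C(CC)(CC)c1ccc(OCS(=O)(=O)c2ccccc2)c(C)c1` is not yet measured. It differs from compound 1 by 3-hydroxy-1-(hydroxymethyl)propyl in place of 1,2-bis(methoxycarbonyl)ethyl on an amide-type nitrogen. Among the measured compounds shown here, the only step that bears on this change is the one from compound 1 to compound 2, which also swapped the diester for a hydroxyl-bearing group and moved the number downward. A step of similar direction and at least similar size is expected here. Compound 3 is therefore estimated at 20000 nM, with a range from 8000 nM to 50000 nM. That estimate corresponds to an expected at least 2.5-fold lower number from compound 1 to compound 3 (0.39 log units; beyond the scatter).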

Compound 3, half-maximal inhibitory concentration: > 50000 nM
Compound 3 gave a limit, no number (the forecaster's own chance of this, stated with the estimate: 35%); middle value at least 2.5-fold (0.39 log units) away from the limit.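

On this amide-type nitrogen, replacing the diester with a hydroxyl-bearing group does not by itself bring a measurable number. In this assay, compound 3, which carries 3-hydroxy-1-(hydroxymethyl)propyl, gives > 50000 nM, a limit of the assay. With 2-hydroxyethyl in place of isopropyl on the saturated chain carbon, the result is an at least 3.7-fold higher number from compound 2 to compound 3 (0.57 log units; beyond the scatter), so among these compounds the measurable number goes with the isopropyl group of compound 2 and not with the hydroxymethyl part that compound 2 shares with compound 3; the step between the two limits, from compound 1 to compound 3, cannot be read: the limit of > 50000 nM in this assay, at which 2 of the 3 values shown sit.

As far as these compounds go, it remains open how far compound 1 and compound 3 lie past that limit. From the compounds shown here alone, it is also open whether a cyclohexyl or benzyl group on that saturated chain carbon would take the number lower than in compound 2.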